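This account rests on a few compounds, and the source may have more. Where it says the series, first, only, none or still open, it means among the compounds named here.

Measured so far:
- compound 1 `CCCC[C@H](NC(=O)[C@H](CCCCN)NC(=O)[C@H](CCCNC(=N)N)NC(=O)c1ccc(/C=C2\SC(=O)N(C3CCCCC3)C2=O)cc1)C(N)=O`: in an ADME assay for permeability, using PAMPA (on this read-out lower numbers stand for lower permeability and higher numbers for higher permeability), compound 1 gives 1.69 10^-6 cm/s
- compound 2 `CCCC[C@H](NC(=O)[C@H](CCCN)NC(=O)[C@H](CCCNC(=N)N)NC(=O)c1ccc(/C=C2\SC(=O)N(Cc3ccccc3)C2=O)cc1)C(N)=O`: in this assay compound 2 is reported only as "impermeable" (no number reported), with no number
- compound 3 `CCCC[C@H](NC(=O)[C@H](CCCCN)NC(=O)[C@H](CCCNC(=N)N)NC(=O)c1ccc(/C=C2\SC(=S)N(c3ccc(Cl)cc3)C2=O)cc1)C(N)=O`: in this assay compound 3 gives 1.02 10^-6 cm/s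

Compound 1 carries the higher of the two numbers recorded in this assay, but its nearest neighbour, compound 3, sits within the usual scatter of it, so the two cannot be ranked against each other. Compound 2 stands apart as the entry for which no number was obtained.

The unmeasured compound 4 `CCCC[C@H](NC(=O)[C@H](CCCCN)NC(=O)[C@H](CCCNC(=N)N)NC(=O)c1ccc(/C=C2\SC(=O)N(Cc3ccc(Cl)cc3)C2=O)cc1)C(N)=O` differs from compound 1 at a single point: 4-chlorobenzyl in place of cyclohexyl on an amide-type nitrogen in a ring. Among the compounds with values here, no pair of measured compounds isolates this exact change, so the step has to be judged from the rough pattern of the three measured compounds. Compound 2, which carries an unsubstituted benzyl at the same position, gave no number at all, and compound 3, with a chlorinated aromatic ring there, gives 1.02 10^-6 cm/s. On that basis compound 4 is expected to land somewhat lower than compound 1, a step of about a 2.1-fold lower number from compound 1 to compound 4 (0.32 log units; beyond the scatter), which may not clearly exceed the scatter. Compound 4 is therefore estimated at 0.8 10^-6 cm/s, with a likely range from 0.2 10^-6 cm/s to 2.5 10^-6 cm/s.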

Compound 4, apparent permeability: 1.11 10^-6 cm/s
Beside the measured number, compound 4's estimate is 1.4-fold (0.14 log units) below it; the range from low to high includes it.
By their numbers in this assay, from the lowest: compounds 3, 4 and 1 (each within the scatter of the next).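

In this assay, the exchange of cyclohexyl for 4-chlorobenzyl on the amide-type nitrogen in the ring gives a 1.5-fold lower number from compound 1 to compound 4 (0.18 log units; within the scatter), so compound 1 and compound 4 cannot be ranked against each other. Within the data shown here, this is the first reading of a single change at this position, and it shows that the read-out stays within the scatter when a six-membered non-aromatic ring of carbon gives way to a six-membered aromatic ring, while the group grows from 6 heavy atoms to 8. Nothing measured here accounts for this result or ties it to any feature of either group.

As far as these compounds go, both groups carry no net charge and have no hydrogen-bond donors or acceptors, so it remains open how a primary amine or a carboxylic acid on a short chain would read at this nitrogen. Also open, from the compounds shown here alone, is what an unsubstituted benzyl would give on the core of compound 1, which would separate the chlorine from the rest of the 4-chlorobenzyl group.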